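The source may report more compounds than this note shows. Statements on the series, on what has been measured and on what is new or still open speak of the compounds shown alone.

Compound 1 `Cc1ccc(NC(=O)C2CCN(C/C=C/c3ccccc3)CC2)cc1` gives 33900 nM
Compound 2 `CCCc1ccc(NC(=O)C2CCN(C/C=C/c3ccccc3)CC2)cc1` gives 9410 nM

Among the measured compounds shown here, in a functional assay on HepG2 cells (Homo sapiens) for inhibition, read by MTT assay, with a stated time of 72 h (a higher number here means a weaker inhibitor, a lower number a stronger inhibitor), compound 2 holds the lower of the two numbers measured so far, at 9410 nM in this series. For the measured compounds named here, compound 3 `O=C(Nc1ccc(F)c(Br)c1)C1CCN(C/C=C/c2ccccc2)CC1` has no measurement yet. It differs from compound 2 by 3-bromo-4-fluorophenyl in place of 4-propylphenyl on an amide-type nitrogen while the shared core stays unchanged.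

Going by the values given here, only one measured step bears on this change, and it is modest. Among the compounds with values here, it concerns the chain on the same aromatic ring, where ethyl in place of hydrogen gave a 3.6-fold lower number from compound 1 to compound 2 (0.56 log units; beyond the scatter) in the only comparison available. Compound 3 has no such chain, so the expectation rests on reading that step backwards, towards a higher number. Within the data shown here, no compound carrying bromine or fluorine has been measured, so the effect of the incoming group remains open. A modest change is therefore expected, estimated as a 1.7-fold higher number from compound 2 to compound 3 (0.23 log units; within the scatter) with real uncertainty. For compound 3 the expected value is 16000 nM within an estimated range from 5000 nM to 45000 nM in this assay here.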

Compound 3, half-maximal inhibitory concentration: 8190 nM
Compound 3: middle estimate off by 2.0-fold (0.29 log units), on the high side, within the range that was stated.
By their numbers in this assay, from the lowest: compounds 3 and 2 (each within the scatter of the next); then compound 1.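

In this assay, putting 3-bromo-4-fluorophenyl in place of 4-propylphenyl on the amide-type nitrogen gives a 1.1-fold lower number from compound 2 to compound 3 (0.06 log units; within the scatter), so a ring with no saturated chain stands level with the ring that carries the propyl chain, and that chain is not required to reach this level. Measured against the 4-methylphenyl group, the same incoming group gives a 4.1-fold lower number from compound 1 to compound 3 (0.62 log units; beyond the scatter), in the same direction as a 3.6-fold lower number from compound 1 to compound 2 (0.56 log units; beyond the scatter), which means that two quite different groups at this place both improve on 4-methylphenyl. Nothing available explains why the two groups end up level in this cell assay.

The compounds shown do not separate the bromine from the fluorine within the 3-bromo-4-fluorophenyl group, so the share of each in this result stays open. Also open, on these data alone, is whether an amine or a carboxylic acid on this ring, or a chain longer than propyl, would hold this level or move beyond it.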